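The source may hold more compounds than are shown below. What is called first, only, known or untested is meant among the compounds shown, and "the series" means these compounds.

In a functional assay on RAW264.7 cells (Mus musculus) for inhibition, read by Griess assay, with stated times of 1 h and 24 h; a higher number here means a weaker inhibitor, a lower number a stronger inhibitor:
- Compound 1 `O=C1OC(Cc2nc(Cc3ccccc3)no2)c2ccccc21`: > 10000 nM
- Compound 2 `COc1cc(OC)c2c(c1)/C(=C/c1ccc(OCc3ccccc3)cc1)OC2=O`: > 10000 nM

Neither entry is a true number. Compound 2 stands at > 10000 nM, which is a limit of the assay. Compound 1 gives > 10000 nM, which is also a limit. The two compounds therefore cannot be ranked against each other, and all the data show so far is the limit of > 10000 nM in this assay, at which 2 of the 2 values shown sit.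

Compound 3 `COc1cc(OC)c2c(c1)/C(=C/c1ccc(OCc3ccc(F)cc3)cc1)OC2=O` keeps the core of compound 2 and alters a single place: fluoro in place of hydrogen on an aromatic carbon. Fluoro takes the place of hydrogen on an aromatic carbon, so the benzyloxy group becomes a (4-fluorobenzyl)oxy group.

Going by the values given here, no pair of measured compounds shows what a swap of this kind does in this assay. The expectation therefore starts from compound 2 at > 10000 nM, and no shift in either direction beyond the usual scatter is foreseen. The expected change, a step that the limit leaves unreadable from compound 2 to compound 3, is accordingly small. The likeliest outcome is that compound 3 also returns only a limit. Compound 3 is estimated at 12000 nM, with an expected range of 5000 nM to 30000 nM.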

Compound 3, half-maximal inhibitory concentration: > 10000 nM
Compound 3: a limit, no number; the forecaster's own chance of this, stated with the estimate: 75%; the middle value lies beyond the limit too.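

Going by these compounds alone, compound 2 and compound 3 each return only a limit in this assay so no step between them can be read. The data so far show one shared ceiling: the limit of > 10000 nM in this assay, at which 3 of the 3 values shown sit. The compounds shown leave open whether fluoro in place of hydrogen changes inhibition at all, and how strongly compound 2 and compound 3 truly inhibit.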